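This account rests on a few compounds, and the source may have more. Where it says the series, first, only, none or still open, it means among the compounds named here.

Measured so far in this assay:
compound 1, `COc1cc(NC(C)CCCN2C(=O)[C@@H](C)N(C(=O)CN)C2(C)C)c2ncccc2c1`: > 3 h
compound 2, `COc1cc(NC(C)CCCN2C(=O)CN(C(=O)[C@H](N)C(C)C)C2(C)C)c2ncccc2c1`: > 3 h
compound 3, `COc1cc(NC(C)CCCN2C(=O)[C@@H](C)NC2(C)C)c2ncccc2c1`: > 3 h

In an ADME assay on a cell-free system (plasma, Homo sapiens) for metabolic stability, with Plasma (Rattus norvegicus) as the target, read by HPLC (on this read-out lower numbers stand for a shorter-lived compound and higher numbers for a longer-lived compound), the value of compound 1 is a limit of this assay, not a number. The value of compound 2 is likewise a limit. The value of compound 3 is also a limit. Compound 2 therefore stands at the limit of > 3 h in this assay, at which 3 of the 3 values shown sit, together with the other two, and nothing separates it from them. For the measured compounds named here, the only measured step, a step that the two limits leave unreadable from compound 1 to compound 3, concerns a different change and its size cannot be read. Going by the values given here, no measured step bears on the change to compound 4, `CC[C@H](C)[C@@H](N)C(=O)N1CC(=O)N(CCCC(C)Nc2cc(OC)cc3cccnc23)C1(C)C`, which differs from compound 2 by methyl in place of hydrogen on a saturated chain carbon, three bonds along the chain from an amine nitrogen and a carbonyl carbon. Compound 4 is expected to remain at the limit, with a number no higher from compound 2 to compound 4 (the limit leaves the size open), giving an estimate of 3 h spanning 2 h to 3 h.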

Compound 4, half-life: > 3 h
Compound 4: only a limit was reported; the forecaster's own chance of this, stated with the estimate: 85%; the middle value sits exactly at the limit.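

Compound 2 and compound 4 both stand at a limit in this assay, so the step between them cannot be read. The compounds shown leave open how long any of them actually lasts, and whether the added methyl changes that at all.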